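A few compounds are considered here, and "the series" means these few. Any claim that something is new, unique, unknown or untested is made for them only; others in the source may bear on it.

Measured compounds, with their values in an assay for inhibition of acyl-CoA:cholesterol acyltransferase (Oryctolagus cuniculus), using microsomes; a higher number here means a weaker inhibitor, a lower number a stronger inhibitor:
Compound 1 `CSc1cc(C)nc(C)c1NC(=O)N(Cc1ccc(Oc2ccc(F)cc2)cc1)C1CCCCCC1`: compound 1 gives 90 nM.
Compound 2 `Cc1cc(C)c(NC(=O)N(Cc2ccc(Oc3ccc(F)cc3)cc2)C2CCCCCC2)c(C)n1`: compound 2 gives 62 nM.
Compound 3 `COc1nc(C)ccc1NC(=O)N(Cc1ccc(Oc2ccc(F)cc2)cc1)C1CCCCCC1`: compound 3 gives 39 nM.

Compound 3 has the lowest number of the three in this assay. Its gap to compound 1, a 2.3-fold lower number from compound 1 to compound 3 (0.36 log units; beyond the scatter), is beyond the scatter, but its gap to compound 2, a 1.6-fold lower number from compound 2 to compound 3 (0.20 log units; within the scatter), is not, so compound 3 and compound 2 cannot be told apart here.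

Compound 4 `Cc1ccc(NC(=O)N(Cc2ccc(Oc3ccc(F)cc3)cc2)C2CCCCCC2)c(Cl)n1` differs from compound 3 by chloro in place of methoxy on an aromatic carbon. Among the measured compounds shown here, the steps that bear on this change are those that alter substituents on the same ring: a 1.5-fold lower number from compound 1 to compound 2 (0.16 log units; within the scatter) stays within the scatter, and a 2.3-fold lower number from compound 1 to compound 3 (0.36 log units; beyond the scatter) is modest. Substituent changes on this ring have so far moved this assay by little. Compound 4 is therefore expected to stay close to compound 3, with a step of a 1.3-fold higher number from compound 3 to compound 4 (0.11 log units; within the scatter), not beyond the scatter. The estimate for compound 4 in this assay is 50 nM, with a range from 20 nM to 130 nM.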

Compound 4, half-maximal inhibitory concentration: 19 nM
The estimate for compound 4 lay 2.6-fold (0.42 log units) above the measured number; measured number below the stated range.
By their numbers in this assay, from the lowest: compound 4; then compounds 3, 2 and 1 (each within the scatter of the next, the first and the last beyond it).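

Among the compounds shown here, replacing methoxy with chloro on the aromatic carbon next to the ring nitrogen gives a 2.1-fold lower number from compound 3 to compound 4 (0.31 log units; beyond the scatter) in this assay, the first step at this position to lie beyond the scatter without any change elsewhere on the ring. Compound 4 also stands apart from the other two ring patterns, with a 3.3-fold lower number from compound 2 to compound 4 (0.51 log units; beyond the scatter) and a 4.7-fold lower number from compound 1 to compound 4 (0.68 log units; beyond the scatter), which makes it the strongest inhibitor of the four, since its steps to all the others lie beyond the scatter. Nothing available here accounts for this gain.

The compounds shown leave open how fluoro, bromo or an amine would behave at this same position. They also leave open whether chloro would keep this advantage with a further group on the ring, such as the methylsulfanyl of compound 1.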